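From a Propoxy Limit to a Trifluoromethoxy Analogue

The compounds below may be only part of what the source reports. "The series", "measured", "known", "first", "only" and "open" are said of these compounds alone.

Measured in a functional assay on KB cells (Homo sapiens) for antiproliferative activity, read by sulforhodamine B assay, with a stated time of 3 days; on this read-out higher numbers stand for an effect only at larger amounts of compound and lower numbers for an effect already at smaller amounts:
- Compound 1 `CCCCc1ccc(-c2cc(=O)c3c(o2)C(CC)(CC)C(=O)C(CC)=C3O)cc1`: 111 uM
- Compound 2 `CCCOc1ccc(-c2cc(=O)c3c(o2)C(CC)(CC)C(=O)C(CC)=C3O)cc1`: > 50.5 uM

For compound 2, the result is only a limit: > 50.5 uM. Compound 3 `CCC1=C(O)c2c(oc(-c3ccc(OC(F)(F)F)cc3)cc2=O)C(CC)(CC)C1=O` carries trifluoromethyl in place of propyl on an oxygen on an aromatic ring, with trifluoromethyl in place of propyl on an oxygen on an aromatic ring. Going by the values given here, the only measured step bearing on this is a step that the limit leaves unreadable from compound 1 to compound 2, so it offers no size to carry over. Among the compounds with values here, the sole exact number remains that of compound 1, 111 uM, so a similarly weak result is expected in this assay. The expected step is a step that the limit leaves unreadable from compound 2 to compound 3, with no direction beyond the scatter anticipated. For compound 3, the estimated value is 70 uM, with an expected range of 30 uM to 150 uM.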

Compound 3, concentration for half-maximal effect: 36.5 uM
Beside the measured number, compound 3's estimate is 1.9-fold (0.28 log units) above it; the measured number falls inside the stated range.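

In this assay, a group joined through oxygen to the aromatic ring now has an exact number, and trifluoromethoxy in place of butyl gives a 3.0-fold lower number from compound 1 to compound 3 (0.48 log units; beyond the scatter). Trifluoromethyl in place of propyl on that oxygen gives an at least 1.3-fold lower number from compound 2 to compound 3 (0.14 log units; that floor lies within the scatter), so this change has only a floor and no full size. Compound 2 remains a limit, which is why that step cannot be sized: the limit of > 50.5 uM in this assay, at which 1 of the 3 values shown sits.

The compounds shown leave open whether the lower number follows from the oxygen link or from the fluorine atoms. They also leave open how a methoxy group or an amine on the aromatic ring would read.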